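Heptyl in place of 4-chlorophenyl: compound 2 to compound 3

The source may hold more compounds than are shown below. What is called first, only, known or untested is meant among the compounds shown, and "the series" means these compounds.

Among the compounds with values here, compound 2 `N#Cc1ccc2[nH]cc(C(c3ccc(Cl)cc3)c3c[nH]c4ccc(C#N)cc34)c2c1` gives 23600 nM in a functional assay on MCF7 cells (Homo sapiens) for inhibition, read by MTT assay, with a stated time of 48 h (a higher number here means a weaker inhibitor, a lower number a stronger inhibitor), the highest of the two numbers so far. Compound 1 `CCCCCCCC(c1c[nH]c2ccc([N+](=O)[O-])cc12)c1c[nH]c2ccc([N+](=O)[O-])cc12` gives 5800 nM in this assay, and the two values lie beyond the scatter of each other. Compound 3 `CCCCCCCC(c1c[nH]c2ccc(C#N)cc12)c1c[nH]c2ccc(C#N)cc12` differs from compound 2 by heptyl in place of 4-chlorophenyl on a saturated chain carbon bound to two aromatic carbons. Within the data shown here, no step between measured compounds is available. Among the measured compounds shown here, the expectation rests on compound 1, the only heptyl-bearing compound measured, at 5800 nM. The expected step is a 3.0-fold lower number from compound 2 to compound 3 (0.47 log units; beyond the scatter), downward and beyond the scatter. Compound 3 is estimated at 8000 nM, with a likely range from 3000 nM to 25000 nM.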

Compound 3, half-maximal inhibitory concentration: 2500 nM
Compound 3: middle estimate off by 3.2-fold (0.51 log units), on the high side; measured number outside the range, below it.
By their numbers in this assay, from the lowest: compound 3; then compound 1; then compound 2.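

With the nitrile groups unchanged, heptyl in place of 4-chlorophenyl on a saturated chain carbon bound to two aromatic carbons gives a 9.4-fold lower number from compound 2 to compound 3 (0.97 log units; beyond the scatter) in this assay. Within the data shown here, this is the only single-place comparison at this position so far. It shows that the aromatic ring is not required there, and that an open chain with the same heavy-atom count gives the lower number.

On these data alone, whether an octyl or pentyl chain, or a heptyl chain ending in an amine or a carboxylic acid, would keep this step remains open. No measured property bears on the cause of the step.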